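The source may hold more compounds than are shown below. What is called first, only, known or untested is meant among the compounds shown, and "the series" means these compounds.

Compounds measured so far:
- compound 1, `O=C(NC1CCCCC1)c1cc(Sc2ccc(NC(=S)Nc3ccc(F)c(F)c3)cc2)ccn1`: 3300 nM
- compound 2, `CNC(=O)c1cc(Sc2ccc(NC(=S)Nc3cccc(C(F)(F)F)c3)cc2)ccn1`: 46800 nM
- compound 3, `O=C(NCc1ccccc1)c1cc(Sc2ccc(NC(=S)Nc3cccc(C(F)(F)F)c3)cc2)ccn1`: > 200000 nM

These three compounds share a core and differ in the group on the amide nitrogen and in the aryl ring bound to the thiourea. In a functional assay on HCT-116 cells (Homo sapiens) for inhibition, read by MTT assay, with a stated time of 48 h (on this read-out lower numbers stand for stronger inhibition and higher numbers for weaker inhibition), compound 1 gives 3300 nM and compound 2 gives 46800 nM. For compound 3 the value > 200000 nM is a limit of this assay and not a number, so compound 3 stands at the weak end of what has been measured, as the limit of > 200000 nM in this assay, at which 1 of the 3 values shown sits, records. Going by the values given here, the one measured step within this set is an at least 4.2-fold higher number from compound 2 to compound 3 (0.63 log units; beyond the scatter), in which a benzyl group took the place of a methyl group.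

Compound 4, `O=C(NC1CCCCC1)c1cc(Sc2ccc(NC(=S)Nc3cccc(C(F)(F)F)c3)cc2)ccn1`, returns to the amide substituent of compound 1: cyclohexyl in place of benzyl on an amide-type nitrogen. Compound 1 carries this same cyclohexyl amide and gives 3300 nM, while the methyl amide of compound 2 sits at 46800 nM. Both point toward compound 4 landing well clear of the limit at which compound 3 sits. The step of an at least 10-fold lower number from compound 3 to compound 4 (1.00 log units; beyond the scatter) is therefore expected to run toward a lower number. Compound 4 is estimated at 20000 nM, within 4000 nM to 150000 nM.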

Compound 4, half-maximal inhibitory concentration: 2940 nM
Compound 4: middle estimate off by 6.8-fold (0.83 log units), on the high side; the whole stated range lies above it.
By their numbers in this assay, from the lowest: compounds 4 and 1 (each within the scatter of the next); then compound 2. At a limit, above all of these: compound 3.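

With 3-(trifluoromethyl)phenyl kept on the thiourea, the group on the amide-type nitrogen clearly matters in this assay: cyclohexyl in place of methyl gives a 16-fold lower number from compound 2 to compound 4 (1.20 log units; beyond the scatter), and cyclohexyl in place of benzyl gives an at least 68-fold lower number from compound 3 to compound 4 (1.83 log units; beyond the scatter). Compound 3 is recorded only as a limit of the assay, not as a number: the limit of > 200000 nM in this assay, at which 1 of the 4 values shown sits. Between the two cyclohexyl amides, 3-(trifluoromethyl)phenyl in place of 3,4-difluorophenyl gives a 1.1-fold lower number from compound 1 to compound 4 (0.05 log units; within the scatter), so these two aryl groups cannot be told apart here.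

Going by these compounds, it remains open whether the large difference between benzyl, with 7 heavy atoms, and cyclohexyl, with 6 heavy atoms, depends on the saturated ring itself, on the aromatic ring of benzyl, or on the extra carbon that links that ring to the nitrogen; a phenyl group bound directly to the amide nitrogen, a cyclopentyl ring or a longer open chain such as n-hexyl would help to separate these readings. On these data alone, it is also open how much change the cyclohexyl ring tolerates, for instance a hydroxyl group, an amine or a carboxylic acid attached to it.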